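The compounds below may be only part of what the source reports. "The series", "measured", "known", "first", "only" and "open" are said of these compounds alone.

Compound 1 `Cc1c(C(=O)CSCCN)[n+]([O-])c2ccccc2[n+]1[O-]` ends in an amine nitrogen, and in an ADME assay on Vero cells (Chlorocebus sabaeus) for cytotoxicity, read by MTT assay, with a stated time of 72 h (on this read-out lower numbers stand for higher toxicity in this test and higher numbers for lower toxicity in this test), compound 1 gives "not determined" (no result reported), so no number stands beside it. Two measured relatives share its core: compound 2 `Cc1ccc(SCC(=O)c2c(C)[n+]([O-])c3ccccc3[n+]2[O-])cc1` gives 50 ug/mL in this assay, and compound 3 `Cc1c(C(=O)CSc2nccs2)[n+]([O-])c2ccccc2[n+]1[O-]` gives 50 ug/mL in this assay. Among the compounds with values here, the single measured step, no change at the digits printed from compound 2 to compound 3 (within the scatter), exchanges one group on the sulfur for another and leaves the read-out where it was. Compound 4 `Cc1c(C(=O)CSCCNC(=O)c2ccc(F)cc2)[n+]([O-])c2ccccc2[n+]1[O-]` differs from compound 1 by (4-fluorophenyl)carbonyl in place of hydrogen on an amine nitrogen. That change sits on the amine nitrogen, a place the measured step did not touch, so it offers no direct guide; both measured values sit together, and no shift beyond the scatter is expected. Compound 4 is therefore estimated at 50 ug/mL, within 20 ug/mL to 120 ug/mL.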

Compound 4, half-maximal cytotoxic concentration: > 100 ug/mL
Compound 4 gave a limit, no number; the forecaster's own chance of this, stated with the estimate: 25%; middle value at least 2.0-fold (0.30 log units) from the limit.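

In this assay, within the data shown here, compound 4 gives a limit, > 100 ug/mL, and compound 1 has no number, so no step between them can be read. On these data alone, how far (4-fluorophenyl)carbonyl in place of hydrogen on the amine nitrogen moves this read-out stays open.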